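The source may report more compounds than this note shows. Statements on the series, on what has been measured and on what is new or still open speak of the compounds shown alone.

Three compounds share one core and differ only in the group attached at one end. Compound 1 `O=C1C(=O)N(Cc2ccc(-c3cccnc3)cc2)c2ccc(OC(F)(F)F)cc21` carries pyridin-3-yl and in a functional assay on CHO cells for positive allosteric modulation of muscarinic acetylcholine receptor M5 (Homo sapiens), read by FLIPR and calcium flux, with a stated time of 1 h (a lower number here means a smaller maximal response, a higher number a larger maximal response), gives 51%. Compound 2 `O=C1C(=O)N(Cc2ccc(Cl)nc2)c2ccc(OC(F)(F)F)cc21` gives 80% in this assay, and compound 3 `O=C1C(=O)N(Cc2ccc(-c3ccncc3)nc2)c2ccc(OC(F)(F)F)cc21` gives 50%. Compound 1 therefore stands second highest of the three numbers: compound 3 sits within the scatter of it, while compound 2 lies beyond the scatter above it. Among the compounds with values here, the only step measured in a single place, a number 30 percentage points lower from compound 2 to compound 3 (beyond the scatter), concerns a pyridin-4-yl ring entering where a chloro stood. Compound 4 `O=C1C(=O)N(Cc2ccc(-c3ccccc3)cc2)c2ccc(OC(F)(F)F)cc21` is not yet measured; it differs from compound 1 as follows: phenyl in place of pyridin-3-yl on an aromatic carbon. Within the data shown here, no measured step swaps a pyridyl ring for a phenyl ring, so that single step bears on the change only loosely, and compound 1 and compound 3, which both carry a pyridyl ring, sit close together. A step within the scatter is therefore expected, a number 4 percentage points higher from compound 1 to compound 4 (within the scatter). Compound 4 is estimated at 55%, with a range from 35% to 75%.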

Compound 4, largest response reached (Emax), in percent of the reference or control that the assay uses: < 60%
Compound 4 gave a limit, no number; the forecaster's own chance of this, stated with the estimate: 0%; the middle value does not contradict the limit.
By their numbers in this assay, from the lowest: compounds 3 and 1 (each within the scatter of the next); then compound 2.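

In this assay compound 4 gave < 60%, which is a limit and not a number. The step from compound 1 to compound 4 therefore cannot be read: the limit of < 60% in this assay, at which 1 of the 4 values shown sits. The compounds shown leave open whether phenyl in place of pyridin-3-yl changes the largest response at all.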